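The source may hold more compounds than are shown below. What is called first, only, known or untested is meant among the compounds shown, and "the series" means these compounds.

Compounds measured in a functional assay for agonist activity at G protein-coupled receptor 88 (Homo sapiens), read by HTRF and cAMP accumulation; a higher number here means that more compound is needed for the effect, a lower number that less compound is needed:
- compound 1, `CC(C)C[C@@H](N)CN(C(=O)[C@@H]1C[C@H]1c1ccccc1)c1ccc(-c2ccccc2)cc1`: 1.8 nM
- compound 2, `N[C@H](CN(C(=O)[C@@H]1C[C@H]1c1ccccc1)c1ccc(-c2ccccc2)cc1)C1CCCCC1`: 0.66 nM
- compound 3, `CC(C)C[C@H](N)CCN(C(=O)[C@@H]1C[C@H]1c1ccccc1)c1ccc(-c2ccccc2)cc1`: 3 nM

Among these three, compound 3 gives the highest number, though the gap to compound 1 is within the scatter, as a 1.7-fold higher number from compound 1 to compound 3 (0.22 log units; within the scatter) shows; only the gap to compound 2 is beyond it, seen in a 4.5-fold higher number from compound 2 to compound 3 (0.66 log units; beyond the scatter).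

Compound 4, `CCC(CC)C(N)CCN(C(=O)[C@@H]1C[C@H]1c1ccccc1)c1ccc(-c2ccccc2)cc1`, differs from compound 3 by one change: 1-amino-2-ethylbutyl in place of 1-amino-3-methylbutyl on a saturated chain carbon, two bonds along the chain from an amide-type nitrogen. Among the measured compounds shown here, no measured step exchanges one open-chain alkyl group for another at this carbon, so none bears directly on it. The nearest is a 2.7-fold lower number from compound 1 to compound 2 (0.44 log units; beyond the scatter), where a different group on the amino-bearing carbon moved the number modestly, and a 4.5-fold higher number from compound 2 to compound 3 (0.66 log units; beyond the scatter), which shows that changes at this position stay within a modest range. The account therefore expects compound 4 to sit close to compound 3 in this assay, with a step of a 1.2-fold lower number from compound 3 to compound 4 (0.08 log units; within the scatter) that is estimated to fall within the scatter. Compound 4 is estimated at 2.5 nM, within a range from 0.8 nM to 8 nM.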

Compound 4, half-maximal effective concentration: 2 nM
Compound 4: the middle estimate sits 1.3-fold (0.10 log units) above what was measured; the measured number falls inside the stated range.
By their numbers in this assay, from the lowest: compound 2; then compounds 1, 4 and 3 (each within the scatter of the next).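

In this assay, exchanging one open-chain group for another at this carbon, with 1-amino-2-ethylbutyl (7 heavy atoms, no defined stereocentre) in place of 1-amino-3-methylbutyl (6 heavy atoms, 1 defined stereocentre), gives a 1.5-fold lower number from compound 3 to compound 4 (0.18 log units; within the scatter). The comparison with the other open-chain compound is also within the scatter, at a 1.1-fold higher number from compound 1 to compound 4 (0.05 log units; within the scatter), whereas a 3.0-fold higher number from compound 2 to compound 4 (0.48 log units; beyond the scatter) keeps the amino(cyclohexyl)methyl compound apart from the three open-chain compounds. Nothing available explains how closely these open-chain compounds agree.

The compounds shown leave open what amino(cyclohexyl)methyl would give on the saturated chain carbon two bonds along from the amide-type nitrogen, where only open-chain groups appear here. They also leave open how the separate stereoisomers of compound 4 compare, and what a hydroxyl in place of the amine would give.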